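The source may report more compounds than this note shows. Statements on the series, on what has been measured and on what is new or still open speak of the compounds shown alone.

For the measured compounds named here, compound 2 `C[C@@H]1CN(c2ncc(F)cn2)CCN1c1ncc(OCc2ccncc2C#N)cn1` holds the highest of the two numbers so far in a functional assay for agonist activity at Glucose-dependent insulinotropic receptor (Mus musculus), read by HTRF and cAMP accumulation, with a stated time of 45 min (on this read-out higher numbers stand for an effect only at larger amounts of compound and lower numbers for an effect already at smaller amounts), giving 567 nM; compound 1 `CC(C)OC(=O)N1CCN(c2ncc(OCc3ccncc3C#N)cn2)[C@H](C)C1` gives 458 nM, and the step of a 1.2-fold higher number from compound 1 to compound 2 (0.09 log units; within the scatter) lies within the scatter, so no order between the two is claimed. Compound 3 `C[C@@H]1CN(c2nc(C3CC3)no2)CCN1c1ncc(OCc2ccncc2C#N)cn1` carries 3-cyclopropyl-1,2,4-oxadiazol-5-yl in place of 5-fluoropyrimidin-2-yl on an amine nitrogen in a ring. Going by the values given here, only one measured step touches this nitrogen: the exchange of isopropoxycarbonyl for 5-fluoropyrimidin-2-yl, a 1.2-fold higher number from compound 1 to compound 2 (0.09 log units; within the scatter), left the number unchanged within the scatter. Among the compounds with values here, that step is the only guide; it shows two unlike groups on this ring amine nitrogen giving the same read-out, and nothing shows what a 3-cyclopropyl-1,2,4-oxadiazol-5-yl does there. For compound 3 a step of a 1.1-fold higher number from compound 2 to compound 3 (0.02 log units; within the scatter) is therefore expected, one not clearly beyond the scatter, with wide uncertainty. The estimate for compound 3 is 600 nM, with a range from 250 nM to 1400 nM.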

Compound 3, half-maximal effective concentration in the Glucose-dependent insulinotropic receptor assay: 158 nM
For compound 3 the middle estimate is 3.8-fold (0.58 log units) above the measured one; measured number outside the range, below it.
By their numbers in the Glucose-dependent insulinotropic receptor assay, from the lowest: compound 3; then compounds 1 and 2 (each within the scatter of the next).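

In the Glucose-dependent insulinotropic receptor assay this ring amine nitrogen no longer looks indifferent to its substituent: 3-cyclopropyl-1,2,4-oxadiazol-5-yl gives a 3.6-fold lower number from compound 2 to compound 3 (0.55 log units; beyond the scatter) and a 2.9-fold lower number from compound 1 to compound 3 (0.46 log units; beyond the scatter), both steps beyond the scatter, where the earlier exchange on this nitrogen stayed within it. In a physicochemical assay for solubility, in phosphate buffer, at pH 7.4 (on this read-out higher numbers stand for higher solubility and lower numbers for lower solubility), compound 2 gives < 600 nM, which is a limit of the assay and not a number. In the physicochemical assay compound 3 gives 14000 nM. Even so, the same change goes with higher solubility in the physicochemical assay, so the lower number in the Glucose-dependent insulinotropic receptor assay does not come with a solubility penalty here: the measured solubility of compound 2, < 600 nM, and of compound 3, 14000 nM, an at least 23-fold higher number (1.36 log units; beyond the scatter)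

The compounds shown do not separate the contribution of the cyclopropyl group from that of the 1,2,4-oxadiazole ring. From the compounds shown here alone, whether a methyl or tert-butyl group on that ring, or a 1,3,4-oxadiazole, would keep either result remains open.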